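Swapping a tert-butylphenyl for a cyanophenyl on the shared core

This account rests on a few compounds, and the source may have more. Where it says the series, first, only, none or still open, it means among the compounds named here.

Compound 1 `COc1cc(-c2ccnc3cc(-c4ccc(C(C)(C)C)cc4)nn23)cc(OC)c1OC` is the weakest measured compound. In a functional assay on MCF7 cells (Homo sapiens) for inhibition, read by CCK-8 assay, with a stated time of 48 h (a lower number here means a stronger inhibitor, a higher number a weaker inhibitor), compound 1 gives only a limit, > 10000 nM, so no number is known for it; it sits at the limit of > 10000 nM in this assay, at which 1 of the 3 values shown sits. Compound 4 `COc1cc(-c2ccnc3cc(-c4cccc(C#N)c4)nn23)cc(OC)c1OC` differs from it by 3-cyanophenyl in place of 4-(tert-butyl)phenyl on an aromatic carbon. Two measured steps start from the same place on compound 1. Compound 2 `COc1ccc(-c2cc3nccc(-c4cc(OC)c(OC)c(OC)c4)n3n2)cc1F` gives 183 nM in this assay, a step of an at least 54-fold lower number from compound 1 to compound 2 (1.73 log units; beyond the scatter). Compound 3 `COc1cc(-c2ccnc3cc(-c4c[nH]c5ccccc45)nn23)cc(OC)c1OC` gives 85 nM, a step of an at least 110-fold lower number from compound 1 to compound 3 (2.07 log units; beyond the scatter). Both replacements of the 4-(tert-butyl)phenyl gave large drops, so a similar large drop is expected for compound 4, estimated at 300 nM (range 80 nM to 2000 nM), an expected step of an at least 33-fold lower number from compound 1 to compound 4 (1.52 log units; beyond the scatter).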

Compound 4, half-maximal inhibitory concentration: > 10000 nM
Compound 4: only a limit was reported (the forecaster's own chance of this, stated with the estimate: 15%); middle value at least 33-fold (1.52 log units) away from the limit.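

Taking the 4-(tert-butyl)phenyl off this aromatic carbon does not by itself give activity in this assay; the group that enters matters. The 3-cyanophenyl falls far behind the other two replacements, with an at least 110-fold higher number from compound 3 to compound 4 (2.07 log units; beyond the scatter) and an at least 54-fold higher number from compound 2 to compound 4 (1.73 log units; beyond the scatter). Compound 1 and compound 4 both give only a limit, so the step between them cannot be read: the limit of > 10000 nM in this assay, at which 2 of the 4 values shown sit.

As far as these compounds go, it remains open whether the nitrile itself or its place on the phenyl ring sets this outcome. Also open, from the compounds shown here alone, is how a phenyl ring carrying an amine or a carboxylic acid instead of the nitrile would behave here.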